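Lengthening the chain from compound 3 to compound 4

The source may hold more compounds than are shown below. What is called first, only, known or untested is meant among the compounds shown, and "the series" means these compounds.

In a functional assay on THP-1 cells (Homo sapiens) for inhibition (a higher number here means a weaker inhibitor of growth, a lower number a stronger inhibitor of growth), compound 1 `Cc1noc(C)c1-c1ccc2c(c1)c(Cc1ccccc1)cn2CCCCCC(=O)NO` gives 15500 nM, compound 2 `Cc1noc(C)c1-c1ccc2c(c1)c(Cc1ccccc1)cn2CCCCCCC(=O)NO` gives 15500 nM and compound 3 `Cc1noc(C)c1-c1ccc2c(c1)c(CCc1ccccc1)cn2CCCCCC(=O)NO` gives 15500 nM, so compound 3 stands level with the other two. Compound 4 `Cc1noc(C)c1-c1ccc2c(c1)c(CCc1ccccc1)cn2CCCCCCC(=O)NO` carries one change: (hydroxycarbamoyl)methyl in place of hydroxycarbamoyl on a saturated chain carbon, five bonds along the chain from an aromatic nitrogen. This places (hydroxycarbamoyl)methyl in place of hydroxycarbamoyl on a saturated chain carbon, five bonds along the chain from an aromatic nitrogen. Among the measured compounds shown here, the same exchange on the shared core was measured as no change at the digits printed from compound 1 to compound 2 (within the scatter), and the only other measured step is no change at the digits printed from compound 1 to compound 3 (within the scatter). Both stay within the scatter, so no step beyond the scatter is expected in this assay. The expected step is no change at the digits printed from compound 3 to compound 4 (within the scatter). For compound 4 the estimated value is 15500 nM, with an expected range of 9000 nM to 22000 nM.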

Compound 4, concentration for 50% growth inhibition: 15500 nM
For compound 4 middle estimate and measured number coincide at the digits printed; measured number inside the range.
By their numbers in this assay, from the lowest: compounds 1, 2, 3 and 4 (each within the scatter of the next).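

In this assay, (hydroxycarbamoyl)methyl in place of hydroxycarbamoyl now reads no change at the digits printed from compound 3 to compound 4 (within the scatter), so this exchange holds on a second core: the same change on two cores in this assay, no change at the digits printed (within the scatter) from compound 1 to compound 2 and no change at the digits printed (within the scatter) from compound 3 to compound 4, 1.0-fold (0.00 log units) apart, within the scatter of two such steps

Benzyl in place of phenyl on a saturated chain carbon bound to an aromatic carbon reads no change at the digits printed from compound 2 to compound 4 (within the scatter), likewise on a second core: the same change on two cores in this assay, no change at the digits printed (within the scatter) from compound 1 to compound 3 and no change at the digits printed (within the scatter) from compound 2 to compound 4, 1.0-fold (0.00 log units) apart, within the scatter of two such steps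

Together the two exchanges complete a set of four compounds in which neither one separates the values.

Open, going by these compounds, is whether a longer chain carrying hydroxycarbamoyl, or a carboxylic acid in place of hydroxycarbamoyl, would separate from these values.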